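A few compounds are considered here, and "the series" means these few. Any claim that something is new, unique, unknown or untested is made for them only; others in the source may bear on it.

Measured so far in a functional assay on C8166 cells (Homo sapiens) for cytotoxicity, read by MTT assay; a higher number here means that more compound is tolerated, a lower number that less compound is tolerated:
Compound 1 `Cc1cc(S(N)(=O)=O)ccc1NC(=O)COc1ccc(Cl)cc1NC(=O)c1ccccc1` gives 207000 nM.
Compound 2 `Cc1cc(S(N)(=O)=O)ccc1NC(=O)COc1ccc(Cl)cc1NC(=O)c1cccc(Cl)c1` gives 59700 nM.
Compound 3 `Cc1cc(S(N)(=O)=O)ccc1NC(=O)COc1ccc(Cl)cc1NC(=O)c1cc(Cl)cc(Br)c1` gives 114000 nM.

Compound 2 holds the lowest number of the three in this assay, though compound 3 sits within the scatter of it and only compound 1 stands clearly apart. Compound 4 `Cc1cc(S(N)(=O)=O)ccc1NC(=O)COc1ccc(Cl)cc1NC(=O)/C=C/c1ccccc1` differs from compound 2 by 2-phenylethenyl in place of 3-chlorophenyl on a carbonyl carbon. Among the compounds with values here, two measured steps bear on this change: a 3.5-fold lower number from compound 1 to compound 2 (0.54 log units; beyond the scatter), where adding the chloro that compound 4 now loses lowered the number, and a 1.9-fold higher number from compound 2 to compound 3 (0.28 log units; within the scatter), which stayed within the scatter. Losing the chloro is therefore expected to move the number back up toward compound 1, while the 2-phenylethenyl has no precedent among these compounds. The step is expected to read a 2.0-fold higher number from compound 2 to compound 4 (0.30 log units; within the scatter). Compound 4 is thus estimated at 120000 nM, with a range from 50000 nM to 300000 nM.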

Compound 4, half-maximal cytotoxic concentration: 163000 nM
For compound 4 the middle estimate is 1.4-fold (0.13 log units) below the measured one; measured number inside the range.
By their numbers in this assay, from the lowest: compounds 2, 3, 4 and 1 (each within the scatter of the next, the first and the last beyond it).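

At this carbonyl carbon, the exchange of 3-chlorophenyl for 2-phenylethenyl gives a 2.7-fold higher number from compound 2 to compound 4 (0.44 log units; beyond the scatter) in this assay and shows that a group with a double bond outside the aromatic ring and no chlorine stands clear of compound 2. Beside the plain phenyl the same group gives a 1.3-fold lower number from compound 1 to compound 4 (0.10 log units; within the scatter) and beside 3-bromo-5-chlorophenyl it gives a 1.4-fold higher number from compound 3 to compound 4 (0.16 log units; within the scatter) and neither step lies beyond the scatter, so compound 4 cannot be separated from compound 1 or compound 3. No supporting measurement accounts for these numbers.

From the compounds shown here alone, it remains open whether the double bond or the missing chlorine underlies the step from compound 2. Going by these compounds, how an amine or a carboxylic acid would read on this carbonyl carbon also stays unknown.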